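Series notes: dechlorination of the cinnamoyl ring on compound 1

The compounds below may be only part of what the source reports. "The series", "measured", "known", "first", "only" and "open" are said of these compounds alone.

Compound 1, `Cc1ccccc1Nc1nc(C)c(C(=O)/C=C/c2ccccc2Cl)s1`, is measured in a functional assay on Bel-7402 cells (Homo sapiens) for cytotoxicity, read by MTT assay (on this read-out lower numbers stand for stronger inhibition and higher numbers for weaker inhibition), and gives only the limit > 25000 nM; it is a limit of the assay, not a number. Compound 2, `Cc1cccc(Nc2nc(C)c(C(=O)/C=C/c3ccccc3Cl)s2)c1`, likewise returns only a limit, > 25000 nM. Compound 3, `COc1cccc(/C=C/C(=O)c2sc(Nc3ccc(Cl)cc3)nc2C)c1`, also sits at a limit, > 25000 nM. Within the data shown here, the single one-place step on record, a step that the two limits leave unreadable from compound 1 to compound 2, with 3-methylphenyl in place of 2-methylphenyl on a nitrogen on an aromatic ring, cannot be read, because both its ends rest at the limit of > 25000 nM in this assay, at which 3 of the 3 values shown sit.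

Compound 4, `Cc1ccccc1Nc1nc(C)c(C(=O)/C=C/c2ccccc2)s1`, differs from compound 1 by hydrogen in place of chloro on an aromatic carbon, 2-chlorophenyl to phenyl. Among the measured compounds shown here, no measured step touches this part of the shared core, and every value shown in this assay is a limit, so the data give no direction and no size for this change. The expected step that the limit leaves unreadable from compound 1 to compound 4 is accordingly none beyond the scatter, and the most likely outcome is that compound 4 again returns only a limit. As a point estimate, compound 4 is expected at 35000 nM, in the range 12000 nM to 120000 nM.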

Compound 4, half-maximal inhibitory concentration: > 25000 nM
Compound 4 was reported as a limit; the forecaster's own chance of this, stated with the estimate: 75%; the middle value is on the limit's open side.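

Compound 4 gives > 25000 nM in this assay, which is a limit and not a number. The change from compound 1 to compound 4 cannot be read, because both ends rest at the same limit: the limit of > 25000 nM in this assay, at which 4 of the 4 values shown sit.

From the compounds shown here alone, whether hydrogen in place of chloro alters cytotoxicity at all, and which change to the shared core would give a readable value, stays open.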